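Blood stability of two phosphonate ester prodrugs and an isothiazole analogue

A few compounds are considered here, and "the series" means these few. Any claim that something is new, unique, unknown or untested is made for them only; others in the source may bear on it.

Measured so far:
compound 1, `CC(C)(C)C(=O)OCO[P@@]1(=O)OCC(C)(C)[C@H](C(=O)NCCC(=O)O)O1`: > 1 h
compound 2, `CCc1cc(C(=O)OCO[P@@]2(=O)OCC(C)(C)[C@H](C(=O)NCCC(=O)OC)O2)n(C)n1`: >= 0.97 h

In an ADME assay on blood (Homo sapiens) for pharmacokinetics (a lower number here means that the compound disappears faster, a higher number that the compound lasts longer), compound 1 reaches only a limit of the assay, > 1 h (the limit of > 1 h in this assay, at which 1 of the 2 values shown sits). In this assay, among the compounds with values here, compound 2 likewise sits at a limit, >= 0.97 h (the limit of >= 0.97 h in this assay, at which 1 of the 2 values shown sits), so both known values are limits and no step between them can be sized. Compound 3, `COC(=O)CCNC(=O)[C@@H]1O[P@@](=O)(OCOC(=O)c2ccns2)OCC1(C)C`, is not yet measured; it differs from compound 2 by 1,2-thiazol-5-yl in place of 3-ethyl-1-methyl-1H-pyrazol-5-yl on a carbonyl carbon. Within the data shown here, no measured step exists for guidance, and the change is expected to bring no step beyond the scatter, a step that the limit leaves unreadable from compound 2 to compound 3. Compound 3 is therefore estimated at 1 h, within 0.5 h to 2 h.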

Compound 3, half-life: < 0.16 h
Compound 3 ended at the assay's limit (the forecaster's own chance of this, stated with the estimate: 65%); at least 6.2-fold (0.79 log units) between middle value and limit.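

In this assay, within the data shown here, 1,2-thiazol-5-yl in place of 3-ethyl-1-methyl-1H-pyrazol-5-yl on a carbonyl carbon gives an at least 6.0-fold lower number from compound 2 to compound 3 (0.78 log units; beyond the scatter), the first step that can be read. The group at this place can therefore change how long the compound lasts, even though both groups are five-membered aromatic rings with 2 hetero atoms. Compound 3 gives < 0.16 h, which is a limit of the assay, so the full size of the step stays unread.

Whether the sulfur or the absence of the ethyl and methyl groups accounts for the step stays open. From the compounds shown here alone, how a phenyl group or an unsubstituted pyrazole ring at this place would behave also stays open.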